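This account rests on a few compounds, and the source may have more. Where it says the series, first, only, none or still open, it means among the compounds named here.

Compound 1 `COc1cc(-c2cc(/C=C/C(=O)c3ccc(N)cc3)[nH]n2)cc(OC)c1OC` gives 2000 nM in a functional assay on MDA-MB-231 cells (Homo sapiens) for inhibition, read by MTT assay, with a stated time of 48 h (a lower number here means a stronger inhibitor, a higher number a weaker inhibitor), and so stands at the lower of the two numbers recorded, though compound 2 `COc1ccc(-c2cc(/C=C/C(=O)c3ccc(N)cc3)[nH]n2)cc1OC` gives 2200 nM and the step of a 1.1-fold higher number from compound 1 to compound 2 (0.04 log units; within the scatter) is within the scatter. Compound 3 `COc1cc(-c2cc(/C=C/C(=O)c3ccc(Cl)cc3)[nH]n2)cc(OC)c1OC` carries chloro in place of amino on an aromatic carbon, para to a large group. For the measured compounds named here, no measured step touches that position; the one step seen concerns a methoxy elsewhere and is within the scatter, so nothing anchors the direction of this exchange. The expected step of a 1.1-fold lower number from compound 1 to compound 3 (0.05 log units; within the scatter) is therefore set near zero with a wide range. For compound 3 the estimate in this assay is 1800 nM, between 500 nM and 6500 nM.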

Compound 3, half-maximal inhibitory concentration: 26000 nM
For compound 3 the middle estimate is 14-fold (1.16 log units) below the measured one; the measured number lies above the stated range.
By their numbers in this assay, from the lowest: compounds 1 and 2 (each within the scatter of the next); then compound 3.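

Unlike the methoxy change, this position responds strongly in this assay: chloro in place of amino gives a 13-fold higher number from compound 1 to compound 3 (1.11 log units; beyond the scatter), a large step. The 4-aminophenyl group of compound 1 is therefore not freely exchangeable for 4-chlorophenyl on this core, and the exchange also takes away the hydrogen-bond donor and acceptor counted on amino. Nothing available explains the size of this step. Open, going by these compounds, is how a hydroxy, a fluoro or a dimethylamino group would read at this position. Also open, on these data alone, is whether the step holds on the core of compound 2.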